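The compounds below may be only part of what the source reports. "The series", "measured", "known", "first", "only" and "open" are said of these compounds alone.

Compound 1 `CCOC(=O)C1=Cc2ccccc2OC1(OCc1cc(-c2ccc(OC)cc2)no1)C(F)(F)F` in a functional assay on A549 cells (Homo sapiens) for inhibition, read by MTT assay, with a stated time of 24 h (on this read-out higher numbers stand for weaker inhibition and lower numbers for stronger inhibition), gives only a limit of the assay, > 150000 nM. Compound 2 `CCCCCCCCn1cc(COC2(C(F)(F)F)Oc3ccccc3C=C2C(=O)OCC)nn1` likewise reaches only a limit in this assay, > 150000 nM. Among the measured compounds shown here, compound 3 `COc1ccc(-c2cc(COC3(C(F)(F)F)Oc4ccccc4C=C3C(=O)O)on2)cc1` is the one compound of the three with a number: in this assay compound 3 gives 36200 nM. For the measured compounds named here, the one step that can be read runs an at least 4.1-fold lower number from compound 1 to compound 3 (0.61 log units; beyond the scatter), and its size as a lower bound rests on (the limit of > 150000 nM in this assay, at which 2 of the 3 values shown sit). Compound 1 therefore stands at the limit, with no number to place it; two of the three values shown sit there.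

Compound 4 `CCOC(=O)C1=Cc2ccccc2OC1(OCc1cc(-c2ccc(Cl)cc2)no1)C(F)(F)F` differs from compound 1 in one place: chloro in place of methoxy on an aromatic carbon. Going by the values given here, no measured step touches this part of the structure; the only step known concerns hydrogen in place of ethyl on an oxygen next to a carbonyl group, a different place on the shared core. So no step bears on the change, and the expectation rests on where compound 1 stands. Because compound 1 gives > 150000 nM, the starting point is a limit. Compound 4 is therefore expected to stay near that limit, a step that the limit leaves unreadable from compound 1 to compound 4, a step of no more than the scatter in either direction. The estimate for compound 4 is 180000 nM, between 60000 nM and 500000 nM.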

Compound 4, half-maximal inhibitory concentration: 19100 nM
Beside the measured number, compound 4's estimate is 9.4-fold (0.97 log units) above it; the measured number lies below the stated range.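

Among the compounds shown here, the first readable step at this place, on an aromatic carbon para to a large group, shows that the group there counts in this assay: the change from 4-methoxyphenyl to 4-chlorophenyl gives an at least 7.8-fold lower number from compound 1 to compound 4 (0.89 log units; beyond the scatter). For the compounds shown here, until now, the only compound with a number carried the free carboxylic acid, whereas compound 4 keeps the ethyl ester of compound 1 and still leaves the limit, so the ethyl ester alone does not hold a compound there, although compound 1 and compound 2 both remain at the limit. The size of the step remains a lower bound, not a measured distance, and the true gap between the two compounds cannot be read: the limit of > 150000 nM in this assay, at which 2 of the 4 values shown sit.

Still open, from the compounds shown here alone, is whether the change is specific to chloro or would also appear with other groups at this place, such as a 4-fluorophenyl, a 4-bromophenyl or a 4-aminophenyl group. Also open, going by these compounds, is whether the 4-chlorophenyl change and the replacement of ethyl by hydrogen add up in a single compound, a carboxylic acid bearing the 4-chlorophenyl group.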